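The source may report more compounds than this note shows. Statements on the series, on what has been measured and on what is new or still open speak of the compounds shown alone.

Compound 1, `CCOc1ccccc1-c1ccc(-c2nc3cnccc3c(N[C@H](CC)C(N)=O)c2C#N)cc1`, in an ADME assay on Caco-2 cells (Homo sapiens) for permeability, read by LC-MS, in the apical to basolateral direction, with a stated time of 2 h, tested at 2 uM; on this read-out lower numbers stand for lower permeability and higher numbers for higher permeability: 151 nm/s.
Compound 2, `N#Cc1c(-c2ccc(Br)cc2)nc2cnccc2c1NCC(N)=O`: 148 nm/s.
Compound 3, `CC[C@@H](Nc1c(C#N)c(-c2ccc(-c3cccc(OC)c3)cc2)nc2cnccc12)C(N)=O`: 104 nm/s.

Compound 3 shows the lowest of the three numbers, yet its gaps to compound 2 and to compound 1 both lie within the scatter of repeated measurements, so the three compounds cannot really be told apart on this read-out.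

Compound 4, `CC[C@@H](Nc1c(C#N)c(-c2ccc(-c3ccccc3OC)cc2)nc2cnccc12)C(N)=O`, has not yet been measured. It is built from the same atoms as compound 3, joined differently: 2-methoxyphenyl in place of 3-methoxyphenyl on an aromatic carbon.

Among the measured compounds shown here, one measured step bears on this change. a 1.5-fold lower number from compound 1 to compound 3 (0.16 log units; within the scatter) shows that moving from a 2-ethoxyphenyl to a 3-methoxyphenyl left the number within the scatter. Compound 4 returns to a group placed like that of compound 1, differing only by the ethoxy being a methoxy, so no step beyond the scatter is expected in this assay, with at most a slight drift back toward the number of compound 1, which gave 151 nm/s.

Compound 4 is therefore estimated at 125 nm/s, within a range of 70 nm/s to 220 nm/s, which means an expected step of a 1.2-fold higher number from compound 3 to compound 4 (0.08 log units; within the scatter).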

Compound 4, apparent permeability: 160 nm/s
Estimate against measurement, compound 4: 1.3-fold (0.11 log units) below; the measured number falls inside the stated range.
By their numbers in this assay, from the lowest: compounds 3, 2, 1 and 4 (each within the scatter of the next).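

In this assay, 2-methoxyphenyl in place of 3-methoxyphenyl gives a 1.5-fold higher number from compound 3 to compound 4 (0.19 log units; within the scatter), so on this ring, para to a large group, the two placements of the methoxy group cannot be told apart. The shorter chain of the 2-methoxyphenyl group, set against the 2-ethoxyphenyl group, gives a 1.1-fold higher number from compound 1 to compound 4 (0.03 log units; within the scatter), so removing that single methyl also leaves no step beyond the scatter. Nothing measured here accounts for how closely these numbers sit together.

Among the compounds shown here, all the groups compared at this position so far are neutral phenyl ethers. As far as these compounds go, whether a carboxylic acid or an amine on that ring, or an alkoxy chain longer than ethoxy, would carry the number beyond the scatter remains open.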